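Replacing the Aromatic Substituent: An Estimate for Compound 3

This account rests on a few compounds, and the source may have more. Where it says the series, first, only, none or still open, it means among the compounds named here.

Measured so far:
Compound 1 `C=C(C)c1ccccc1OC(C)C1=NCCN1`: 603 nM
Compound 2 `CC(Oc1ccccc1S(C)(=O)=O)C1=NCCN1`: 3800 nM

In an assay on CHO cells for displacement of a labelled ligand from Alpha-2C adrenergic receptor (Homo sapiens) (on this read-out lower numbers stand for stronger inhibition and higher numbers for weaker inhibition), compound 1 gives 603 nM, the lowest of the two numbers. The nearest is compound 2, reached by a 6.3-fold higher number from compound 1 to compound 2 (0.80 log units; beyond the scatter). Compound 3 `CC(=O)c1ccccc1OC(C)C1=NCCN1` differs from compound 1 by acetyl in place of 1-methylethenyl on an aromatic carbon. Going by the values given here, only one measured step bears on this: the change from compound 1 to compound 2 also removed 1-methylethenyl from that aromatic carbon, and it gave a 6.3-fold higher number from compound 1 to compound 2 (0.80 log units; beyond the scatter), a modest shift. A similar direction is therefore expected here, with a 2.5-fold higher number from compound 1 to compound 3 (0.40 log units; beyond the scatter). Compound 3 is estimated at 1500 nM, in a range from 500 nM to 4500 nM.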

Compound 3, inhibition constant: 7410 nM
Compound 3: the middle estimate sits 4.9-fold (0.69 log units) below what was measured; the measured number lies above the stated range.
By their numbers in this assay, from the lowest: compound 1; then compounds 2 and 3 (each within the scatter of the next).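

Putting acetyl in place of 1-methylethenyl on this aromatic carbon gives a 12-fold higher number from compound 1 to compound 3 (1.09 log units; beyond the scatter) as a large step, even though both groups have the same count of heavy atoms and one double bond outside aromatic rings. The two replacements land close together, with a 2.0-fold higher number from compound 2 to compound 3 (0.29 log units; within the scatter) as their difference, while compound 1 stays apart from both. Nothing available explains this difference.

From the compounds shown here alone, an amine or a carboxylic acid on the same aromatic carbon remains open. So does whether a longer carbon chain there would give a number nearer compound 1 or nearer the other two.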